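Thiophene in place of thiazole on a benzyl-type carbon

The compounds below may be only part of what the source reports. "The series", "measured", "known", "first", "only" and "open" are said of these compounds alone.

Of the compounds shown here, two of a shared core have been measured in an assay on isolated protein for displacement of a labelled ligand from prostaglandin E2 receptor EP1 subtype (Homo sapiens); a lower number here means a stronger inhibitor, a higher number a weaker inhibitor. Compound 1 `Cc1cc(C(=O)O)cn1Cc1cc(Cl)ccc1OCc1ccccc1` gives 158 nM in this assay. Compound 2 `O=C(O)c1cnc(Cc2cc(Cl)ccc2OCc2ccccc2)s1` gives 631 nM in this assay, the higher of the two numbers, and the gap to compound 1 lies beyond the usual scatter of this assay, so compound 2 is the weaker of the two measured compounds.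

Compound 3 `O=C(O)c1ccc(Cc2cc(Cl)ccc2OCc2ccccc2)s1` is not yet measured. It differs from compound 2 in one place: 5-carboxythiophen-2-yl in place of 5-carboxy-1,3-thiazol-2-yl on a saturated chain carbon bound to an aromatic carbon. The aromatic ring that carries the carboxylic acid is kept as a five-membered ring, and only its ring nitrogen is exchanged for a carbon.

Going by the values given here, no measured pair shows this exact exchange, so the size of the step rests on judgement alone. Because compound 2 stands at 631 nM and compound 1 at 158 nM, the acid-bearing ring seems to tolerate variation without a large shift. The step from compound 2 to compound 3 in this assay is expected to be a 1.6-fold lower number from compound 2 to compound 3 (0.20 log units; within the scatter), a modest move toward a lower number or none beyond the scatter. Compound 3 is therefore estimated at 400 nM, with a range from 150 nM to 1000 nM.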

Compound 3, half-maximal inhibitory concentration in the prostaglandin E2 receptor EP1 subtype assay: 50.1 nM
Compound 3: middle estimate off by 8.0-fold (0.90 log units), on the high side; measured number below the stated range.
By their numbers in the prostaglandin E2 receptor EP1 subtype assay, from the lowest: compound 3; then compound 1; then compound 2.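

In the prostaglandin E2 receptor EP1 subtype assay, 5-carboxythiophen-2-yl in place of 5-carboxy-1,3-thiazol-2-yl gives a 13-fold lower number from compound 2 to compound 3 (1.10 log units; beyond the scatter), so this position responds strongly to the exchange of a single ring atom. The heavy-atom count and the carboxylic acid stay the same, while one ring hetero atom and one hydrogen-bond acceptor leave with the ring nitrogen. In a physicochemical assay for lipophilicity, at pH 7.8 (a lower number here means a more polar compound, a higher number a more lipophilic compound), compound 2 gives 0.9 and compound 3 gives 2.3. The same exchange also makes the compound clearly more lipophilic in the physicochemical assay, so the stronger inhibition may go with this rise, though one pair cannot separate it from the loss of the ring nitrogen itself: the measured distribution coefficient of compound 2, 0.9, and of compound 3, 2.3, a number 1.40 log units higher (beyond the scatter)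

The compounds shown therefore leave open whether inhibition at this position follows lipophilicity or depends on the ring nitrogen as such. They also do not tell how a methyl or a fluorine on the 5-carboxythiophen-2-yl group, or an amide in place of its carboxylic acid, would shift the number in the prostaglandin E2 receptor EP1 subtype assay.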